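A few compounds are considered here, and "the series" means these few. Any claim that something is new, unique, unknown or untested is made for them only; others in the source may bear on it.

Compound 1 `N#Cc1ccc(-c2nc(NCCNc3ccc([N+](=O)[O-])c(N)n3)ncc2-c2ncc[nH]2)cc1` carries a 4-cyanophenyl group on the shared core. In an ADME assay on microsomes from liver (Canis lupus familiaris) for metabolic stability (on this read-out higher numbers stand for a longer-lived compound and lower numbers for a shorter-lived compound), compound 1 gives > 0.5 h, which is a limit of the assay and not a number. Compound 2 `Nc1nc(NCCNc2ncc(-c3ncc[nH]3)c(-c3ccc(C(F)(F)F)cc3)n2)ccc1[N+](=O)[O-]` returns > 0.5 h in this assay, again a limit rather than a number. Compound 3 `Nc1nc(NCCNc2ncc(-c3ncc[nH]3)c(-c3ccccc3Br)n2)ccc1[N+](=O)[O-]` shows > 0.5 h in this assay, also a limit. All three values sit at the limit of > 0.5 h in this assay, at which 3 of the 3 values shown sit, so compound 1 can be placed no more precisely than at that limit itself, with nothing above it resolved. Within the data shown here, the steps a step that the two limits leave unreadable from compound 1 to compound 2, a step that the two limits leave unreadable from compound 1 to compound 3 and a step that the two limits leave unreadable from compound 2 to compound 3 accordingly tell only that the aryl group on that carbon has been exchanged without the half-life falling under the limit. Compound 4 `Nc1nc(NCCNc2ncc(-c3ncc[nH]3)c(-c3ccc(F)cc3C(F)(F)F)n2)ccc1[N+](=O)[O-]` differs from compound 1 in a single place: 4-fluoro-2-(trifluoromethyl)phenyl in place of 4-cyanophenyl on an aromatic carbon. The three measured steps bear on this change, but none of them has a readable size, so no step beyond the scatter is anticipated in either direction. Compound 4 is therefore expected at 1 h, between 0.5 h and 3 h. The expected step is a step that the limit leaves unreadable from compound 1 to compound 4.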

Compound 4, half-life: > 0.5 h
Compound 4: only a limit was reported; the forecaster's own chance of this, stated with the estimate: 80%; the middle value does not contradict the limit.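

Among these compounds, the steps from compound 1, compound 2 and compound 3 to compound 4 cannot be read, so this result yields no new step: the limit of > 0.5 h in this assay, at which 4 of the 4 values shown sit. In this assay the compounds shown leave open how far each half-life extends past that limit, and whether exchanging the aryl group changes it.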